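From Isobutyl to Phenyl on the Amide Nitrogen

A few compounds are considered here, and "the series" means these few. Any claim that something is new, unique, unknown or untested is made for them only; others in the source may bear on it.

compound 1, `COc1ccc2oc(C(=O)N(Cc3cccs3)c3ccn[nH]3)cc2c1`: 1.1 nM
compound 2, `Cc1ccc(OCC(=O)N(Cc2cccs2)CC(C)C)cc1`: 900 nM
compound 3, `CCN(Cc1cccs1)C(=O)COc1ccc(F)cc1`: 422 nM

In an assay on HEK293 cells for agonist activity at transient receptor potential cation channel subfamily M member 8 (Homo sapiens), read by fluorescence and calcium flux, with a stated time of 15 min (on this read-out higher numbers stand for an effect only at larger amounts of compound and lower numbers for an effect already at smaller amounts), compound 2 gives 900 nM, the highest of the three numbers. Compound 3 gives 422 nM, beyond the scatter from compound 2, and compound 1, built on a different core, gives 1.1 nM. Compound 4, `Cc1ccc(OCC(=O)N(Cc2cccs2)c2ccccc2)cc1`, has not been measured. It differs from compound 2 in one place: phenyl in place of isobutyl on an amide-type nitrogen. Going by the values given here, no step between measured compounds covers this change; the values of compound 1 and compound 2 show only that an aromatic group on the amide nitrogen, in another framework, goes with a far lower number. A moderate step toward lower numbers is expected for a 3.0-fold lower number from compound 2 to compound 4 (0.48 log units; beyond the scatter). Compound 4 is estimated at 300 nM, with a range from 60 nM to 1500 nM.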

Compound 4, half-maximal effective concentration: 23 nM
The estimate for compound 4 lay 13-fold (1.12 log units) above the measured number; measured number outside the range, below it.
By their numbers in this assay, from the lowest: compound 1; then compound 4; then compound 3; then compound 2.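

In this assay, phenyl in place of isobutyl on the amide-type nitrogen gives a 39-fold lower number from compound 2 to compound 4 (1.59 log units; beyond the scatter) within a single framework. The link between an aromatic group on this nitrogen and a low number, so far seen only across different frameworks, now holds for a change in this one place, and the step is large. Nothing shown here bears on why the step is so large.

The compounds shown do not tell whether a cyclohexyl ring, a benzyl group or a pyridine ring on this nitrogen would match phenyl. As far as these compounds go, whether the change would carry over to the core of compound 1 also remains open.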